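This account rests on a few compounds, and the source may have more. Where it says the series, first, only, none or still open, it means among the compounds named here.

Compound 1 `CCOc1ccc(/C=C/C(=O)Nc2nc(-c3c(C)cc(C)cc3C)cs2)cc1`: 2480 nM
Compound 2 `COCCOc1ccc(/C=C/C(=O)Nc2nc(-c3c(C)cc(C)cc3C)cs2)cc1`: 1490 nM
Compound 3 `Cc1cc(C)c(-c2csc(NC(=O)/C=C/c3ccc(N4CCCCC4)cc3)n2)c(C)c1`: 4060 nM

In a functional assay on K562 cells (Homo sapiens) for inhibition, read by MTT assay, with a stated time of 96 h (a lower number here means a stronger inhibitor, a higher number a weaker inhibitor), compound 1 stands second highest of the three numbers; its nearest neighbour is compound 3 at a 1.6-fold higher number from compound 1 to compound 3 (0.21 log units; within the scatter), while compound 2 lies at a 1.7-fold lower number from compound 1 to compound 2 (0.22 log units; within the scatter). Compound 4 `Cc1cc(C)c(-c2csc(NC(=O)/C=C/c3ccccc3)n2)c(C)c1` differs from compound 1 by hydrogen in place of ethoxy on an aromatic carbon. Among the compounds with values here, no measured step removes the group at this aromatic carbon outright; the steps that bear on it exchange one group there for another, a 1.6-fold higher number from compound 1 to compound 3 (0.21 log units; within the scatter) and a 2.7-fold higher number from compound 2 to compound 3 (0.44 log units; beyond the scatter), both small. A step of at most modest size is therefore expected in this assay, leaning toward a weaker inhibitor. The estimated step is a 1.4-fold higher number from compound 1 to compound 4 (0.15 log units; within the scatter). Compound 4 is expected to give about 3500 nM, within a range from 1500 nM to 8000 nM.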

Compound 4, half-maximal inhibitory concentration: 40400 nM
Beside the measured number, compound 4's estimate is 12-fold (1.06 log units) below it; measured number outside the range, above it.
By their numbers in this assay, from the lowest: compounds 2, 1 and 3 (each within the scatter of the next, the first and the last beyond it); then compound 4.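

In this assay, exchanges among ethoxy, 2-methoxyethoxy and piperidin-1-yl had moved the number far less than removing the group does: a 16-fold higher number from compound 1 to compound 4 (1.21 log units; beyond the scatter), a 27-fold higher number from compound 2 to compound 4 (1.43 log units; beyond the scatter) and a 10-fold higher number from compound 3 to compound 4 (1.00 log units; beyond the scatter). At this aromatic carbon, para to a large group, having one of these three groups therefore counts for more than which one it is. No measurement available here explains this gap.

From the compounds shown here alone, whether a methyl or a hydroxyl at this carbon would restore the number remains open. So does whether a dimethylamino group or a longer ether chain would match the groups already shown.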